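The source may report more compounds than this note shows. Statements on the series, on what has been measured and on what is new or still open speak of the compounds shown alone.

Compound 2 `NC1=NC2(CCOCC2)N(OCCCOc2ccccc2Cl)C(N)=N1` was tested in a functional assay on MDA-MB-231 cells (Homo sapiens) for antiproliferative activity, read by MTT assay, with a stated time of 72 h (on this read-out higher numbers stand for weaker inhibition and lower numbers for stronger inhibition), where compound 2 gives 1430 nM. Among the measured compounds shown here, of the two compounds measured so far, that is the higher number, which here means the weaker effect. For the measured compounds named here, the other measured compound, compound 1 `NC1=NC2(CCSCC2)N(OCCCOc2ccc(Br)cc2)C(N)=N1`, gives 440 nM in this assay; compound 1 differs from compound 2 in more than one place, so the two values show only that compound 1 sits lower, by a gap beyond the usual scatter.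

The next compound, compound 3 `NC1=NC2(CCOCC2)N(OCCCOc2cccc(Br)c2)C(N)=N1`, has not yet been measured. It differs from compound 2 in a single place: 3-bromophenyl in place of 2-chlorophenyl on an oxygen on a saturated carbon. Going by the values given here, no pair of measured compounds isolates this change, so there is no direct guide to its size. Compound 1, which also carries bromine, gives 440 nM, but its core differs as well, so it is only a loose hint. The step expected a 1.6-fold lower number from compound 2 to compound 3 (0.20 log units; within the scatter) is modest, toward a lower number, and may not exceed the scatter. Compound 3 is therefore estimated to give 900 nM in this assay, with a range from 350 nM to 2500 nM.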

Compound 3, half-maximal inhibitory concentration: 400 nM
Compound 3: the middle estimate sits 2.3-fold (0.35 log units) above what was measured; measured number inside the range.
By their numbers in this assay, from the lowest: compounds 3 and 1 (each within the scatter of the next); then compound 2.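

In this assay, replacing 2-chlorophenyl with 3-bromophenyl on an oxygen on a saturated carbon gives a 3.6-fold lower number from compound 2 to compound 3 (0.55 log units; beyond the scatter), a shift larger than repeat measurements would normally produce. The earlier pair could not show this, since its two compounds differ in more than one place; here the shared core and the chain stay the same, so the difference in number can be tied to this end group alone. Nothing measured here gives a reason for the shift.

The change swaps chlorine for bromine and also alters where the halogen sits on the ring, and these two parts move together in this single step, so the compounds shown cannot tell which of them matters, or whether both do. On these data alone, it also remains open how this end of the molecule would respond to a plain phenyl with no halogen, to a phenyl carrying a nitrile or a methoxy group, or to a longer chain leading to the ring.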